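Removing the hydroxyl-bearing ring from the amine substituent

The source may hold more compounds than are shown below. What is called first, only, known or untested is meant among the compounds shown, and "the series" means these compounds.

Of the compounds shown here, three sharing one core have been measured in an assay on isolated protein for binding affinity to adenosine receptor A1 (Bos taurus); a higher number here means a weaker inhibitor, a lower number a stronger inhibitor. Compound 1 `CCCNc1nc(-c2ccccc2)nc2c1nnn2Cc1ccccc1F` gives 3200000 nM. Compound 2 `OCCCNc1nc(-c2ccccc2)nc2c1nnn2Cc1ccccc1` gives 21400000 nM. Compound 3 `OC1CCC(Nc2nc(-c3ccccc3)nc3c2nnn3Cc2ccccc2)CC1` gives 2700000 nM. On these numbers compound 3 carries the lowest value of the three, but it stands within the scatter of compound 1 and is separated only from compound 2, as the step of a 7.9-fold lower number from compound 2 to compound 3 (0.90 log units; beyond the scatter) shows.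

Compound 4 `CCCNc1nc(-c2ccccc2)nc2c1nnn2Cc1ccccc1` differs from compound 3 in one place: propyl in place of 4-hydroxycyclohexyl on a nitrogen on an aromatic ring. Among the measured compounds shown here, the only measured step at this nitrogen is the one from compound 2 to compound 3, which swapped 3-hydroxypropyl for 4-hydroxycyclohexyl and gave a 7.9-fold lower number from compound 2 to compound 3 (0.90 log units; beyond the scatter). That step removes a chain and brings in a ring with the hydroxyl kept; the present change removes both the ring and the hydroxyl. For the measured compounds named here, no measured pair isolates that. Compound 1 also bears propyl on this nitrogen, though with a fluorine elsewhere, and its value sits within the scatter of compound 3. From this it is expected that the step of a 1.3-fold higher number from compound 3 to compound 4 (0.11 log units; within the scatter) will be small, if anything towards a higher number. Compound 4 is therefore estimated at 3500000 nM, with a range from 1400000 nM to 9000000 nM.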

Compound 4, inhibition constant: 37000000 nM
Compound 4: the middle estimate sits 11-fold (1.02 log units) below what was measured; the whole stated range lies below it.
By their numbers in this assay, from the lowest: compounds 3 and 1 (each within the scatter of the next); then compounds 2 and 4 (each within the scatter of the next).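

In this assay the 4-hydroxycyclohexyl group now stands apart from both open chains on this nitrogen: with no fluorine on any of the three compounds, the change to propyl gives a 14-fold higher number from compound 3 to compound 4 (1.14 log units; beyond the scatter), whereas the hydroxyl on the chain makes no readable difference, the change from hydroxy to hydrogen giving a 1.7-fold higher number from compound 2 to compound 4 (0.24 log units; within the scatter). Among the compounds shown here, compound 1 also proves to be no stand-in for its counterpart without fluorine, since hydrogen in place of fluoro on an aromatic carbon gives a 12-fold higher number from compound 1 to compound 4 (1.06 log units; beyond the scatter), so a change away from the amine substituent also produces a large step. Nothing available explains either large step.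

What the compounds shown leave open is whether the ring alone or the hydroxyl on it carries the difference from the propyl compound, a question that a plain cyclohexyl group on this nitrogen would settle. Also open, from the compounds shown here alone, is whether the fluoro step carries over to the 4-hydroxycyclohexyl compound, and whether chloro or methoxy in place of fluoro would give a step of the same kind.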